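Chain step from compound 2 to compound 4

This account rests on a few compounds, and the source may have more. Where it says the series, first, only, none or still open, it means among the compounds named here.

Measured in an ADME assay on HEK293 cells (Homo sapiens) for cytotoxicity, read by luminescence, with a stated time of 72 h (on this read-out lower numbers stand for an effect already at smaller amounts and higher numbers for an effect only at larger amounts of compound), each value a limit:
- compound 1 `CCOC(=O)c1c(-c2cccc(OCC)c2)[nH]c2cc(OC)ccc2c1=O`: > 22000 nM
- compound 2 `CCOC(=O)c1c(-c2cccc(Oc3ccccc3)c2)[nH]c2cc(OC)ccc2c1=O`: > 22000 nM
- compound 3 `CCOC(=O)c1c(-c2cccc(NC(C)=O)c2)[nH]c2cc(OC)ccc2c1=O`: > 22000 nM

Going by the values given here, the series so far shows (the limit of > 22000 nM in this assay, at which 3 of the 3 values shown sit). Compound 2 has only a limit in this assay, > 22000 nM, and no number.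

Compound 4 `COc1ccc2c(=O)c(C(=O)OCCCN(C)C)c(-c3cccc(Oc4ccccc4)c3)[nH]c2c1` is not yet measured. Its difference from compound 2 is (dimethylamino)methyl in place of hydrogen on a saturated chain carbon, two bonds along the chain from an oxygen next to a carbonyl group. In other words, (dimethylamino)methyl stands in place of hydrogen on a saturated chain carbon, two bonds along the chain from an oxygen next to a carbonyl group, which also reads as ethoxy to 3-(dimethylamino)propoxy.

Among the compounds with values here, three measured steps bear on this only loosely: a step that the two limits leave unreadable from compound 1 to compound 2, a step that the two limits leave unreadable from compound 1 to compound 3 and a step that the two limits leave unreadable from compound 2 to compound 3. None has a readable size, and none touches the chain changed here, so no step size carries over.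

The expectation therefore rests on compound 2 at > 22000 nM, which is a limit. The expected change is small, toward an effect at smaller amounts if a number appears at all, and a further limit is about as likely: an at least 1.2-fold lower number from compound 2 to compound 4 (0.08 log units; that floor lies within the scatter). For compound 4 the estimated value is 18000 nM, with an expected range from 6000 nM to 30000 nM.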

Compound 4, half-maximal effective concentration: > 22000 nM
Compound 4: no number, only a limit; the forecaster's own chance of this, stated with the estimate: 55%; middle value at least 1.2-fold (0.08 log units) from the limit.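

In this assay compound 4 gives > 22000 nM, a limit and not a number. Going by these compounds alone, compound 2 also has only a limit, so no step from compound 2 to compound 4 can be read. The series stays where it was: the limit of > 22000 nM in this assay, at which 4 of the 4 values shown sit.

The compounds shown leave open whether any change to the ester chain or the shared core would yield a number at all.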